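A few compounds are considered here, and "the series" means these few. Any claim that something is new, unique, unknown or untested is made for them only; others in the source may bear on it.

Within the data shown here, in a physicochemical assay for solubility, at pH 7.4 (a lower number here means a less soluble compound, a higher number a more soluble compound), compound 1 `CC[C@H]1[C@@H](N)CN1c1c(F)cc2c(=O)c(C(=O)O)cn(C3CC3)c2c1F` gives 55.9 ug/mL, and this is the single number it has so far produced in this assay. Compound 2 `CC1(N)CN(c2c(F)cc3c(=O)c(C(=O)O)cn(C4CC4)c3c2F)C1`, which carries a different four-membered ring on the same core, has been measured repeatedly and gives 0.8 ug/mL; 15.3 ug/mL (2 entries); its entries spread widely, as seen in the several entries of compound 2 in this assay, 0.8 ug/mL; 15.3 ug/mL (2 entries), so comparing the two compounds is done only with caution, and no step between them is shown.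

Compound 3 `C[C@@H]1[C@@H](N(C)C)CN1c1c(F)cc2c(=O)c(C(=O)O)cn(C3CC3)c2c1F` has not yet been measured in this assay. It differs from compound 1 in one place: a group of 8 heavy atoms (6 carbon, 2 nitrogen; one four-membered non-aromatic ring with 1 hetero atom) in place of a group of 7 heavy atoms (5 carbon, 2 nitrogen; one four-membered non-aromatic ring with 1 hetero atom), on an aromatic carbon. Among the measured compounds shown here, no measured pair in this set shows a step of this kind, so both the direction and the size of the change remain open from the data alone.

The expectation is that compound 3 dissolves somewhat less than compound 1, a step of a 1.9-fold lower number from compound 1 to compound 3 (0.27 log units; within the scatter) in this assay, which would still sit inside the usual scatter of repeated measurements. Compound 3 is therefore estimated at 30 ug/mL, with a range from 8 ug/mL to 120 ug/mL.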

Compound 3, solubility: 97.1 ug/mL
The estimate for compound 3 lay 3.2-fold (0.51 log units) below the measured number; measured number inside the range.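

In this assay, among these compounds, placing a group of 8 heavy atoms on the aromatic carbon in place of a group of 7 heavy atoms gives a 1.7-fold higher number from compound 1 to compound 3 (0.24 log units; within the scatter) and is the first step at this position that can be read. The four-membered ring stays in both groups, while the count of hydrogen-bond donors goes from 1 in the group that leaves to 0 in the group that enters, and this exchange yields no difference that can be told apart from scatter in this assay. Each of these two compounds rests on one number here, and that calls for care, as entries for a single compound in this set can lie far apart: the several entries of compound 2 in this assay, 0.8 ug/mL; 15.3 ug/mL (2 entries).

The compounds shown leave open how much room this position allows, as every group here keeps a four-membered ring with 1 hetero atom, so a six-membered piperazine ring in its place remains untested in this set. On these data alone, it is also open whether a hydroxyl group or a longer chain on the four-membered ring would produce a step that stands clear of the scatter.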